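The source may hold more compounds than are shown below. What is called first, only, known or untested is meant among the compounds shown, and "the series" means these compounds.

Measured so far:
Compound 1 `C=C(CC)C(=O)c1ccc(OCC(=O)NCCCN2CCCC2=O)c(Cl)c1Cl`: 13800 nM
Compound 2 `C=C(CC)C(=O)c1ccc(OCC(=O)Nc2ccc(/C=C/C(=O)NO)cc2)c(Cl)c1Cl`: 2600 nM

In a functional assay on CLL cells (Homo sapiens) for cytotoxicity, read by MTT assay, with a stated time of 48 h (on this read-out lower numbers stand for an effect already at smaller amounts and higher numbers for an effect only at larger amounts of compound), compound 2 gives 2600 nM and compound 1 gives 13800 nM as the higher number. Compound 2 therefore stands lowest of the two, with a gap beyond the usual scatter.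

Compound 3 `C=C(CC)C(=O)c1ccc(OCC(=O)Nc2ccc(C(C)=O)cc2)c(Cl)c1Cl` differs from compound 2 in one place, with acetyl in place of 2-(hydroxycarbamoyl)ethenyl on an aromatic carbon as the counted change. Within the data shown here, no measured pair shows this change, so any forecast in this assay is loose. Compound 1 also lacks 2-(hydroxycarbamoyl)ethenyl and gives 13800 nM in a different side chain, which points to a higher number rather than a lower one. The expected change is a rise beyond the scatter, estimated as a 2.7-fold higher number from compound 2 to compound 3 (0.43 log units; beyond the scatter) here. For compound 3 the estimated value is 7000 nM with an expected range from 2500 nM to 20000 nM in the measurement to come.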

Compound 3, half-maximal effective concentration: 3900 nM
Beside the measured number, compound 3's estimate is 1.8-fold (0.25 log units) above it; low and high end bracket the measured number.
By their numbers in this assay, from the lowest: compounds 2 and 3 (each within the scatter of the next); then compound 1.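

In this assay, acetyl in place of 2-(hydroxycarbamoyl)ethenyl on the aromatic carbon gives a 1.5-fold higher number from compound 2 to compound 3 (0.18 log units; within the scatter), so a number in this range does not depend on the larger group with its hydrogen-bond donors. The gap between compound 1 and compound 2 could not be traced to 2-(hydroxycarbamoyl)ethenyl alone, and the new step on the amide-type nitrogen, 4-acetylphenyl in place of 3-(2-oxopyrrolidin-1-yl)propyl, gives a 3.5-fold lower number from compound 1 to compound 3 (0.55 log units; beyond the scatter), a modest change that points to this side chain instead. Nothing measured here explains either step.

Going by these compounds, whether other groups on this aromatic carbon, such as an amine or a carboxylic acid, would give a similar number remains open. So does how a longer chain between the amide-type nitrogen and the aromatic ring would read out.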